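A few compounds are considered here, and "the series" means these few. Any claim that something is new, unique, unknown or untested is made for them only; others in the source may bear on it.

Compound 3, `CC(C)N1C(=O)C(=O)N=C1/N=C(\NCC(C)(C)C)Nc1ccc(Cl)c(Cl)c1`, was tested in an in vitro ADME assay on microsomes from liver (Homo sapiens) for metabolic stability, read by LC-MS; on this read-out lower numbers stand for a shorter-lived compound and higher numbers for a longer-lived compound. There compound 3 gives > 1 h, which is a limit of the assay and not a number. Its two neighbours carry the same kind of result. Compound 1, `C=CCON/C(=N\C1=NC(=O)C(=O)N1C(C)C)Nc1ccc(Cl)c(Cl)c1`, gives > 1 h in this assay, again a limit. Compound 2, `CC(C)N/C(=N\C1=NC(=O)C(=O)N1C(C)C)Nc1ccc(Cl)c(Cl)c1`, gives > 1 h in this assay, also a limit. Because all three sit at the limit of > 1 h in this assay, at which 3 of the 3 values shown sit, the steps between them cannot be read: a step that the two limits leave unreadable from compound 1 to compound 2, a step that the two limits leave unreadable from compound 1 to compound 3 and a step that the two limits leave unreadable from compound 2 to compound 3. Compound 4, `CC(C)N1C(=O)C(=O)N=C1/N=C(\NCCCN(C)C)Nc1ccc(Cl)c(Cl)c1`, differs from compound 3 by 2-(dimethylamino)ethyl in place of tert-butyl on a saturated chain carbon bound to an amine nitrogen. Within the data shown here, none of the measured steps speaks to this change, each being hidden by its limit. The only ground for an expectation is that compound 3 and its two neighbours all reach (the limit of > 1 h in this assay, at which 3 of the 3 values shown sit). On that ground compound 4 is expected to be long-lived as well, with an estimated step that the limit leaves unreadable from compound 3 to compound 4. The estimate for compound 4 in this assay is 1.5 h, with a range from 0.4 h to 4 h.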

Compound 4, half-life: > 1 h
Compound 4 was reported as a limit (the forecaster's own chance of this, stated with the estimate: 55%); the middle value lies beyond the limit too.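

Among these compounds, no step from compound 1, compound 2 or compound 3 to compound 4 can be read in this assay, because all four compounds sit at the same limit: the limit of > 1 h in this assay, at which 4 of the 4 values shown sit. The compounds shown leave open how long each actually lasts in this assay, and whether the different groups on the amine nitrogen change that half-life at all.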